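The compounds below may be only part of what the source reports. "The series", "measured", "known", "first", "only" and "open" are said of these compounds alone.

Measured in a physicochemical assay for solubility, with a stated time of 24 h, at pH 2.2; a higher number here means a more soluble compound, a lower number a less soluble compound:
Compound 1 `O=C(NC[C@@H]1[C@H]2CN(C(=O)NCc3cc(Cl)cc(Cl)c3)C[C@@H]12)c1ccc2[nH]c(=O)oc2c1`: < 1 ug/mL, a limit.
Compound 2 `N#Cc1cc(COC(=O)N2C[C@@H]3[C@@H](CNC(=O)N4CCc5[nH]nnc5C4)[C@@H]3C2)cc(C(=O)OC(F)(F)F)c1`: 32 ug/mL.

Among the compounds with values here, compound 2 holds the only actual number so far, 32 ug/mL. Compound 1 gives no number, and its reading is the limit of < 1 ug/mL in this assay, at which 1 of the 2 values shown sits.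

Compound 3 `N#Cc1cc(COC(=O)N2C[C@@H]3[C@@H](CNC(=O)N4CCc5c(O)noc5C4)[C@@H]3C2)cc(C(=O)OC(F)(F)F)c1` has not yet been measured in this assay. It keeps the rest of compound 2 and differs only in the group on a carbonyl carbon whose other neighbours are an amide-type nitrogen: a group of 10 heavy atoms (6 carbon, 2 nitrogen, 2 oxygen; one five-membered aromatic ring with 2 hetero atoms, one six-membered non-aromatic ring with 1 hetero atom) in place of a group of 9 heavy atoms (5 carbon, 4 nitrogen; one five-membered aromatic ring with 3 hetero atoms, one six-membered non-aromatic ring with 1 hetero atom), on a carbonyl carbon. Both groups hold one five-membered aromatic ring and one six-membered non-aromatic ring, and the exchange alters the hetero atoms and adds one heavy atom.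

Within the data shown here, no measured step shows what such an exchange does, so the expectation can lean only on compound 2 at 32 ug/mL. A small drop or no change beyond the scatter is expected, and a 1.5-fold lower number from compound 2 to compound 3 (0.16 log units; within the scatter) is the estimated step. For compound 3 the estimated value is 22 ug/mL, with an expected range from 7 ug/mL to 65 ug/mL.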

Compound 3, solubility: < 1 ug/mL
Compound 3 ended at the assay's limit; the forecaster's own chance of this, stated with the estimate: 10%; middle value at least 22-fold (1.34 log units) from the limit.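

In this assay, within the data shown here, the group on a carbonyl carbon whose other neighbours are an amide-type nitrogen proves able to decide the reading on its own: an at least 32-fold lower number from compound 2 to compound 3 (1.50 log units; beyond the scatter) is the first step, and it lies beyond the scatter with the rest of compound 2 unchanged. Both groups hold one five-membered aromatic ring, one six-membered non-aromatic ring and 1 hydrogen-bond donor, so keeping these features does not preserve the reading; the exchange alters the hetero atoms, takes the count from 2 to 3 hydrogen-bond acceptors and adds one heavy atom. Compound 3 gives < 1 ug/mL in this assay as a limit and not a number, so the step gives only a minimum size, and the lower end of the assay now holds a second compound: the limit of < 1 ug/mL in this assay, at which 2 of the 3 values shown sit.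

Among these compounds, the single step cannot separate the change in hetero atoms from the added heavy atom, and it gives no cause for the loss. On these data alone, how an amine or a carboxylic acid on the five-membered aromatic ring would read at this position remains open, as does the true size of the step.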